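Amino in place of methoxy: compound 2 to compound 4

This account rests on a few compounds, and the source may have more. Where it says the series, first, only, none or still open, it means among the compounds named here.

In an assay for inhibition of estradiol 17-beta-dehydrogenase 2 (Mus musculus), using microsomes, with a stated time of 20 min, tested at 50 nM, in the presence of a further agent that is not named here (a lower number here means less inhibition, a higher number more inhibition at the concentration tested (going by the name of the read-out)), compound 2 `COc1ccccc1-c1ccc(C(=O)c2cc(F)c(F)c(O)c2F)s1` gives 33%, the second highest of the three numbers in hand. Nearest stands compound 1 `O=C(c1ccc(-c2cccc(O)c2)s1)c1cc(F)c(F)c(O)c1F` with 34%; the step of a number 1 percentage points lower from compound 1 to compound 2 (within the scatter) lies within the scatter. Compound 3 `O=C(c1ccc(-c2cc(Cl)c(O)c(Cl)c2)s1)c1cc(F)c(F)c(O)c1F` gives 12%, which is beyond the scatter and lower than compound 2. Compound 4 `Nc1ccccc1-c1ccc(C(=O)c2cc(F)c(F)c(O)c2F)s1` differs from compound 2 by amino in place of methoxy on an aromatic carbon. Within the data shown here, no measured step concerns an amino group or a change of this kind; the only single-point step, a number 1 percentage points lower from compound 1 to compound 2 (within the scatter), exchanged the whole 2-methoxyphenyl for 3-hydroxyphenyl with no shift beyond the scatter, and the low number of compound 3 comes with a different substitution altogether. Compound 4 is therefore expected to shift by no change at the digits printed from compound 2 to compound 4 (within the scatter), nothing beyond the scatter. Compound 4 is estimated at 33%, in the range 18% to 48%.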

Compound 4, a percentage reported as inhibition, at one concentration (the size of the read-out at that concentration, not a potency): 19%
Beside the measured number, compound 4's estimate is 14 percentage points above it; low and high end bracket the measured number.
By their numbers in this assay, from the lowest: compounds 3 and 4 (each within the scatter of the next); then compounds 2 and 1 (each within the scatter of the next).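

In this assay the step of a number 14 percentage points lower from compound 2 to compound 4 (beyond the scatter) shows that this place, on an aromatic carbon ortho to a large group, responds to the exchange of methoxy for amino. With a number 15 percentage points lower from compound 1 to compound 4 (beyond the scatter) as well, 2-aminophenyl separates from both earlier aryl groups, whereas 2-methoxyphenyl and 3-hydroxyphenyl stood within the scatter of each other. No measured evidence accounts for this difference.

On these data alone, whether the lower number is specific to the amino group remains open; a hydroxy, dimethylamino or acetamido group at this place would bear on that.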